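The compounds below may be only part of what the source reports. "The series", "measured", "known", "first", "only" and "open" are said of these compounds alone.

Compound 1, whose structure is `CCCSc1nc(N)nc2c1ncn2/C=C1/CC1(CO)CO`, was tested in an ADME assay on MOLT-3 cells (Homo sapiens) for cytotoxicity, with a stated time of 7 days; a lower number here means that less compound is tolerated, a higher number that more compound is tolerated. In this assay compound 1 gives > 20000 nM, which is a limit of the assay rather than a number. Compound 2, with the structure `Nc1nc2c(ncn2/C=C2/CC2(CO)CO)c(=O)[nH]1`, was also tested; in this assay compound 2 gives > 20000 nM, again a limit and not a measured number. So both values shown stand at the same place, namely (the limit of > 20000 nM in this assay, at which 2 of the 2 values shown sit), and compound 1 cannot be ranked against any other compound on these numbers.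

Compound 3, with the structure `CSc1nc(N)nc2c1ncn2/C=C1/CC1(CO)CO`, has not yet been measured. It differs from compound 1 in one place: hydrogen in place of ethyl on a saturated chain carbon bound to a sulfur. No measured pair of compounds shows a step of this kind, so there is no shown size to lean on. The expected step in this assay, from compound 1 to compound 3, is a step that the limit leaves unreadable from compound 1 to compound 3, that is, no change beyond the usual scatter, because compound 1 sits at the limit of > 20000 nM in this assay, at which 2 of the 2 values shown sit, and the shorter chain gives no reason drawn from these compounds to expect otherwise. Compound 3 is therefore estimated to give 25000 nM in this assay, with a range from 10000 nM to 60000 nM, most likely again only as a limit.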

Compound 3, half-maximal cytotoxic concentration: > 20000 nM
Compound 3: a limit, no number; the forecaster's own chance of this, stated with the estimate: 85%; the middle value lies beyond the limit too.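

Compound 3 gives > 20000 nM in this assay, which is a limit and not a number. Compound 1 also stands at a limit, so no step between compound 1 and compound 3 can be read: the limit of > 20000 nM in this assay, at which 3 of the 3 values shown sit.

The compounds shown leave open whether methylsulfanyl and propylsulfanyl differ at all in cytotoxicity.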